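Thieno-fused core: amine swap with both anchors at the assay limit

A few compounds are considered here, and "the series" means these few. Any claim that something is new, unique, unknown or untested is made for them only; others in the source may bear on it.

Of the compounds shown here, two have been measured in a functional assay on L02 cells (Homo sapiens) for inhibition, read by Griess assay, with stated times of 1 h and 24 h; a higher number here means a weaker inhibitor, a lower number a stronger inhibitor. Compound 1, `CCCc1nn(C)c2c(NCc3ccc(F)cc3)nc(/C=C/c3nc(C)c(C)nc3C)nc12`, gives > 1000000 nM there, a limit of the assay and not a number. Compound 2, `COc1cc(/C=C/c2nc(N3CCN(C)CC3)c3sccc3n2)cc(OC)c1OC`, likewise gives > 1000000 nM in this assay, again only a limit. Among the measured compounds shown here, compound 2 therefore stands where both values shown sit, as recorded in the limit of > 1000000 nM in this assay, at which 2 of the 2 values shown sit; no measured step between compounds differing in one place is available, so nothing on the size of such a change is known from the data.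

Compound 3, `COc1cc(/C=C/c2nc(NCc3ccccc3)c3sccc3n2)cc(OC)c1OC`, differs from compound 2 by benzylamino in place of 4-methylpiperazin-1-yl on an aromatic carbon. For the measured compounds named here, no measured step guides this change; the two values shown both sit at the limit. For compound 3 in this assay an estimate of 1000000 nM is made, with a range from 300000 nM to 3000000 nM. The change expected from compound 2 to compound 3 is a number no higher from compound 2 to compound 3 (the limit leaves the size open), that is, no step beyond the scatter, and a further limit rather than a number is the most likely outcome.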

Compound 3, half-maximal inhibitory concentration: > 1000000 nM
Compound 3: a limit, no number (the forecaster's own chance of this, stated with the estimate: 85%); the middle value sits exactly at the limit.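

In this assay no step can be read between compound 2 and compound 3, as each gives a limit and not a number: the limit of > 1000000 nM in this assay, at which 3 of the 3 values shown sit.

The compounds shown leave open what size of change benzylamino in place of 4-methylpiperazin-1-yl brings, and whether any compound of the series gives a number in this assay.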